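Methoxy for Methyl in a Cell Cytotoxicity Series

The source may hold more compounds than are shown below. What is called first, only, known or untested is meant among the compounds shown, and "the series" means these compounds.

Measured so far in an ADME assay on RAW264.7 cells (Mus musculus) for cytotoxicity, read by MTT assay, with a stated time of 48 h; a higher number here means a weaker inhibitor, a lower number a stronger inhibitor:
compound 1, `Cc1cc(NC(=O)c2ccc(Cl)cc2)ccc1NS(C)(=O)=O`, gives 69100 nM;
compound 2, `Cc1cc(NC(=O)c2cccc(C(F)(F)F)c2)ccc1NS(C)(=O)=O`, gives 110000 nM;
compound 3, `COc1cc(NC(=O)c2ccc(Cl)cc2)ccc1NS(C)(=O)=O`, gives 70000 nM.

Compound 3 differs from compound 1 by methoxy in place of methyl on an aromatic carbon. That change made a 1.0-fold higher number from compound 1 to compound 3 (0.01 log units; within the scatter). How the core of compound 2 differs from that of compound 1 is not broken down here; the two numbers are within the scatter of each other.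

Compound 4, `COc1cc(NC(=O)c2cccc(C(F)(F)F)c2)ccc1NS(C)(=O)=O`, is not yet measured. It differs from compound 2 by methoxy in place of methyl on an aromatic carbon, the same change as from compound 1 to compound 3. The step is expected to be no change at the digits printed from compound 2 to compound 4 (within the scatter), because the earlier step was a 1.0-fold higher number from compound 1 to compound 3 (0.01 log units; within the scatter). Compound 4 is therefore estimated at 110000 nM, expected between 55000 nM and 220000 nM.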

Compound 4, half-maximal inhibitory concentration: 84800 nM
Beside the measured number, compound 4's estimate is 1.3-fold (0.11 log units) above it; measured number inside the range.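

In this assay, putting methoxy in place of methyl gave a 1.3-fold lower number from compound 2 to compound 4 (0.11 log units; within the scatter). Set beside the earlier step, the change reads the same on both cores, since the two steps do not differ beyond the scatter: the same change on two cores in this assay, a 1.0-fold higher number (0.01 log units; within the scatter) from compound 1 to compound 3 and a 1.3-fold lower number (0.11 log units; within the scatter) from compound 2 to compound 4, 1.3-fold (0.12 log units) apart, within the scatter of two such steps. This shows that the swap carried over on these two cores without moving the number beyond the scatter, but it does not show that it would do so on other cores or in other assays.

The compounds shown leave open what a different group on that aromatic carbon would do, such as an amine, a carboxylic acid or a longer chain. They also leave open whether the methanesulfonamido group matters, since it stays the same throughout.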